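Cyclobutyl for Cyclobutylmethyl on a Second Amine Core

The source may report more compounds than this note shows. Statements on the series, on what has been measured and on what is new or still open speak of the compounds shown alone.

Compound 1 `CC(C)c1nc(-c2nnc(C3CCN(C4CCC4)CC3)o2)c2ccccn12` and compound 2 `CC(C)c1nc(-c2nnc(C3CCN(CC4CCC4)CC3)o2)c2ccccn12` share one core. In a functional assay on CHO cells for agonist activity at 5-hydroxytryptamine receptor 4 (Homo sapiens), read by a luciferase reporter and cAMP accumulation, with a stated time of 4 h (on this read-out higher numbers stand for an effect only at larger amounts of compound and lower numbers for an effect already at smaller amounts), compound 1 gives 840 nM and compound 2 gives 520 nM. The change cyclobutyl in place of cyclobutylmethyl on an amine nitrogen in a ring produced a 1.6-fold higher number from compound 2 to compound 1 (0.21 log units; within the scatter). Compound 3 `CC(C)c1nc(C(=O)NC[C@@H]2[C@H]3CN(CC4CCC4)C[C@@H]23)c2ccccn12` rests on a different core; the difference between the two cores is not broken down here. In this assay compound 3 gives 13.2 nM, the lowest of the three numbers. Compound 4 `CC(C)c1nc(C(=O)NC[C@@H]2[C@H]3CN(C4CCC4)C[C@@H]23)c2ccccn12` is not yet measured; it carries the same kind of change, (cyclobutyl in place of cyclobutylmethyl on an amine nitrogen in a ring), though here the place is a five-membered non-aromatic ring within a fused or bridged system rather than a six-membered ring. Because the earlier step was a 1.6-fold higher number from compound 2 to compound 1 (0.21 log units; within the scatter), the step from compound 3 is expected to be small, about a 1.4-fold higher number from compound 3 to compound 4 (0.13 log units; within the scatter). For compound 4 the estimate in this assay is 18 nM, expected between 8 nM and 45 nM.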

Compound 4, half-maximal effective concentration: 18 nM
For compound 4 middle estimate and measured number coincide at the digits printed; the measured number falls inside the stated range.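

In this assay the change from cyclobutylmethyl to cyclobutyl on an amine nitrogen in a ring gave a 1.4-fold higher number from compound 3 to compound 4 (0.13 log units; within the scatter) on the second core. The step matches the one seen on the first core: the same change on two cores in this assay, a 1.6-fold higher number (0.21 log units; within the scatter) from compound 2 to compound 1 and a 1.4-fold higher number (0.13 log units; within the scatter) from compound 3 to compound 4, 1.2-fold (0.07 log units) apart, within the scatter of two such steps. The change therefore carried from one core to the other without a step beyond the scatter in these two pairs, but two pairs cannot establish a rule for the whole series, and neither shows what the change would do on any further core.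

The compounds shown leave open how a smaller group such as methyl, or a longer chain such as cyclobutylethyl, would fare on that nitrogen. They also leave open whether an amine nitrogen bearing only hydrogen would give a similar number on both cores.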